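Aryl urea series: alkyl growth and drawn configuration

The source may report more compounds than this note shows. Statements on the series, on what has been measured and on what is new or still open speak of the compounds shown alone.

Compound 1 `Cc1cccc(NC(=O)N[C@@H](C)c2ccccc2)c1` gives 100% in an ADME assay on the whole organism with Oryza sativa as the target, tested at 10 uM; on this read-out lower numbers stand for a stronger effect and higher numbers for a weaker effect at the one concentration tested. Compound 3 `CCc1cccc(NC(=O)N[C@@H](C)c2ccccc2)c1` gives 86%; the change methyl in place of hydrogen on a saturated chain carbon bound to an aromatic carbon brought a number 14 percentage points lower from compound 1 to compound 3 (beyond the scatter). Compound 2 `CCc1cccc(NC(=O)N[C@H](C)c2ccccc2)c1` gives 36%, the lowest of the three numbers, and from it a number 50 percentage points higher from compound 2 to compound 3 (beyond the scatter), a step that rests on (the fact that compounds 2 and 3 differ only in the configuration as drawn). How the core of compound 2 differs from the core of compound 1 is not broken down here. Compound 4 `CC(C)c1cccc(NC(=O)N[C@H](C)c2ccccc2)c1` is not yet measured. It carries the same kind of change that leads from compound 1 to compound 3, namely (methyl in place of hydrogen on a saturated chain carbon bound to an aromatic carbon and a saturated chain carbon), though the place is now a saturated chain carbon bound to an aromatic carbon and a saturated chain carbon rather than one bound to an aromatic carbon. The step is expected to be a number 8 percentage points lower from compound 2 to compound 4 (within the scatter), modest and in the same direction as a number 14 percentage points lower from compound 1 to compound 3 (beyond the scatter), resting on that single precedent. Compound 4 is expected to give 28%, within 8% to 58%.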

Compound 4, a percentage reported as activity, at one concentration (the size of the read-out at that concentration, not a potency): 44%
Compound 4: the middle estimate sits 16 percentage points below what was measured, and the stated range covers the measured number.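

In this assay the new step reads a number 8 percentage points higher from compound 2 to compound 4 (within the scatter), so on this core methyl in place of hydrogen, the change from ethyl to isopropyl, gives no step beyond the scatter. Set beside the earlier step, the change does not carry over unchanged from one core to the other: the same change on two cores in this assay, a number 14 percentage points lower (beyond the scatter) from compound 1 to compound 3 and a number 8 percentage points higher (within the scatter) from compound 2 to compound 4, 22 percentage points apart, beyond the scatter of two such steps. This rests on a single pair of steps whose places also differ, and it shows neither why the two steps part nor how the change would read on further cores.

The compounds shown leave open whether drawn configuration matters with isopropyl as it does with ethyl. Also open, from the compounds shown here alone, is how a tert-butyl group or a longer chain such as propyl would read in that place.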